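The source may report more compounds than this note shows. Statements on the series, on what has been measured and on what is new or still open speak of the compounds shown alone.

Compound 1 `COc1ccccc1/C=C1\CCC/C(=C\c2cccc(OC)c2OC)C1=O`: 14100 nM
Compound 2 `COc1cccc(/C=C2\CCC/C(=C\c3cc(OC)c(OC)c(OC)c3)C2=O)c1OC`: 2300 nM

In a functional assay on HT-1080 cells (Homo sapiens) for cytotoxicity, read by MTT assay, with a stated time of 72 h (a lower number here means a stronger inhibitor, a higher number a weaker inhibitor), compound 1 gives 14100 nM, the higher of the two numbers, and so the weaker of the two inhibitors; compound 2 gives 2300 nM, a lower number that lies beyond the usual scatter. Compound 3 `COc1cccc(/C=C2\CCC/C(=C\c3ccc(O)c(Cl)c3)C2=O)c1OC` has not yet been measured. It differs from compound 1 by 3-chloro-4-hydroxyphenyl in place of 2-methoxyphenyl on a double-bonded chain carbon bound to a double-bonded ring carbon. For the measured compounds named here, no measured pair covers this exact change, so any expectation rests on thin ground. A modest move toward a lower number is expected, a 2.4-fold lower number from compound 1 to compound 3 (0.37 log units; beyond the scatter), with wide uncertainty. In this assay compound 3 is estimated at 6000 nM, within a range from 1500 nM to 25000 nM.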

Compound 3, half-maximal inhibitory concentration: 14300 nM
The estimate for compound 3 lay 2.4-fold (0.38 log units) below the measured number, within the range that was stated.
By their numbers in this assay, from the lowest: compound 2; then compounds 1 and 3 (each within the scatter of the next).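

In this assay, 3-chloro-4-hydroxyphenyl in place of 2-methoxyphenyl on a double-bonded chain carbon bound to a double-bonded ring carbon gives a 1.0-fold higher number from compound 1 to compound 3 (0.01 log units; within the scatter) and so leaves the two compounds indistinguishable. At this position, one substituted phenyl ring can thus stand in for another, even with a hydrogen-bond donor added, without a readable difference in this assay. No outside measurement bears on this result.

Going by these compounds, because both groups were exchanged together, the separate contributions of the chlorine and the hydroxyl stay unknown, and the two could even offset each other. Also open, on these data alone, is how an amine, a carboxylic acid or a longer chain at this position would read.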